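Swapping 1-phenylethyl for 4-aminocyclohexyl on the shared core

The source may hold more compounds than are shown below. What is called first, only, known or untested is meant among the compounds shown, and "the series" means these compounds.

Compound 1 `O=C(NCc1ccc(F)cc1)c1nc(NCCO)c2cccnc2c1O`: "not determined" (no result reported)
Compound 2 `C[C@@H](Nc1c(C(=O)NCc2ccc(F)cc2)nc(Br)c2cccnc12)c1ccccc1`: > 20000 nM
Compound 3 `NCCCNc1c(C(=O)NCc2ccc(F)cc2)nc(Br)c2cccnc12`: 18000 nM

In a functional assay on HCT-116 cells (Homo sapiens) for cytotoxicity, read by MTT assay, with a stated time of 72 h (a higher number here means a weaker inhibitor, a lower number a stronger inhibitor), compound 2 gives > 20000 nM as a limit of the assay, not a number. Compound 4 `N[C@H]1CC[C@H](Nc2c(C(=O)NCc3ccc(F)cc3)nc(Br)c3cccnc23)CC1` carries one change from compound 2: 4-aminocyclohexyl in place of 1-phenylethyl on a nitrogen on an aromatic ring and so 4-aminocyclohexyl replaces 1-phenylethyl on a nitrogen on an aromatic ring. For the measured compounds named here, only one measured step bears on this: an at least 1.1-fold lower number from compound 2 to compound 3 (0.04 log units; that floor lies within the scatter) with 3-aminopropyl as the incoming group. That single step gives little to go on, so only a modest move toward lower numbers is expected, and another limit remains possible. The expected step is an at least 1.6-fold lower number from compound 2 to compound 4 (0.22 log units; that floor lies within the scatter) and it is only an estimate. For compound 4 the estimated value is 12000 nM within an expected range of 3500 nM to 30000 nM in this assay as the read-out.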

Compound 4, half-maximal inhibitory concentration: 4000 nM
Beside the measured number, compound 4's estimate is 3.0-fold (0.48 log units) above it; the measured number falls inside the stated range.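

In this assay, for the compounds shown here, 4-aminocyclohexyl on this nitrogen gives an at least 5.0-fold lower number from compound 2 to compound 4 (0.69 log units; beyond the scatter), the first step here that clears the scatter. Compound 2 stands at a limit, not a number: the limit of > 20000 nM in this assay, at which 1 of the 4 values shown sits. Both 3-aminopropyl and 4-aminocyclohexyl carry an amino group, yet the ring in place of the open chain goes with a 4.5-fold lower number from compound 3 to compound 4 (0.65 log units; beyond the scatter), so an amino group alone does not set the number at this position.

On these data alone, how a plain cyclohexyl or a 4-hydroxycyclohexyl group would compare on this nitrogen stays open, so the share of the amino group in this gain remains unknown.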